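The source may hold more compounds than are shown below. What is called first, only, known or untested is meant among the compounds shown, and "the series" means these compounds.

Working notes on the series. In a functional assay on SW480 cells (Homo sapiens) for antiproliferative activity, read by MTT assay, with a stated time of 48 h (on this read-out lower numbers stand for stronger inhibition and higher numbers for weaker inhibition), compound 1 (`CCCCCCCC(CCO)n1cnc2c(Cl)ncnc21`) gives 3630 nM and compound 2 (`CCCCCCCC(CCO)n1cnc2c(OC)ncnc21`) gives 23900 nM. Compound 2 therefore holds the higher of the two numbers, which makes it the weaker inhibitor of the pair.

The next structure is compound 3 (`CCCCCCCC(CCO)n1cnc2c(N(C)C)ncnc21`), with dimethylamino in place of methoxy on an aromatic carbon of the shared core: dimethylamino in place of methoxy on an aromatic carbon.

Going by the values given here, only one measured step bears on this change: a 6.6-fold higher number from compound 1 to compound 2 (0.82 log units; beyond the scatter), a modest step with methoxy in place of chloro at the same place. It shows that a change of group there can move the number beyond the scatter. Among the compounds with values here, it involves chloro, however, and no measured pair compares methoxy with dimethylamino, so it sets no direction for the new exchange.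

In this assay, a step smaller than the measured one is expected, most likely within the scatter and with no firm direction. The estimated step is a 1.2-fold lower number from compound 2 to compound 3 (0.08 log units; within the scatter). For compound 3 the expected value is 20000 nM, with an estimated range from 8000 nM to 50000 nM.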

Compound 3, half-maximal inhibitory concentration: > 50000 nM
Compound 3: a limit, no number; the forecaster's own chance of this, stated with the estimate: 15%; middle value at least 2.5-fold (0.39 log units) from the limit.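

In this assay compound 3 gives > 50000 nM, which is a limit of the assay and not a number. Even so, the exchange at this place can be read in one direction, with dimethylamino in place of methoxy giving an at least 2.0-fold higher number from compound 2 to compound 3 (0.32 log units; beyond the scatter); this is the first measured comparison of these two groups here, and it runs the same way as the earlier change from chloro to methoxy. With dimethylamino in place of chloro giving an at least 13-fold higher number from compound 1 to compound 3 (1.13 log units; beyond the scatter), the three groups fall in the order chloro, methoxy, dimethylamino from lower to higher numbers, though both new steps are bounds and their true sizes cannot be read from the one compound that sits at the limit: the limit of > 50000 nM in this assay, at which 1 of the 3 values shown sits.

Still open, from the compounds shown here alone, is whether an unsubstituted amine, a methylamino group or another halogen such as bromo at this place would stay near chloro or move towards the limit. Going by these compounds, it is also open whether this order among the three groups would hold with a shorter chain in place of the hydroxyl-bearing chain on the shared core.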